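A few compounds are considered here, and "the series" means these few. Any claim that something is new, unique, unknown or untested is made for them only; others in the source may bear on it.

Measured in a functional assay on HeLa cells (Homo sapiens) for cytotoxicity, read by MTT assay, with a stated time of 24 h; a higher number here means a weaker inhibitor, a lower number a stronger inhibitor:

Compound 1, `COc1cc(/C=C2\CN(C)C/C(=C\c3ccc(F)cc3)C2=O)cc(OC)c1`: 10200 nM
Compound 2, `COc1cc(/C=C2\CN(C)C/C(=C\c3ccc(Cl)cc3)C2=O)cc(OC)c1`: 11200 nM
Compound 3, `CN1C/C(=C\c2ccc(F)cc2)C(=O)/C(=C/c2cccc([N+](=O)[O-])c2)C1`: 6250 nM

Compound 1 and compound 2 share one core and differ in a single place: chloro in place of fluoro on an aromatic carbon. That change produced a 1.1-fold higher number from compound 1 to compound 2 (0.04 log units; within the scatter), so the two values sit together. Compound 3 is built on another core; the difference between the two cores is not broken down here. Its value in this assay and those of compound 1 and compound 2 all lie within the usual scatter of one another, so no order among the three can be read.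

Compound 4, `CN1C/C(=C\c2ccc(Cl)cc2)C(=O)/C(=C/c2cccc([N+](=O)[O-])c2)C1`, has not yet been measured. It differs from compound 3 by chloro in place of fluoro on an aromatic carbon, which is the same change, at the same kind of place, as that from compound 1 to compound 2. For the measured compounds named here, a step of similar size is therefore expected in this assay, namely a 1.1-fold higher number from compound 3 to compound 4 (0.05 log units; within the scatter), because the single earlier instance of this change gave a 1.1-fold higher number from compound 1 to compound 2 (0.04 log units; within the scatter). On that basis compound 4 is estimated at 7000 nM, with a likely range from 3500 nM to 14000 nM.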

Compound 4, half-maximal inhibitory concentration: > 20000 nM
Compound 4: no number, only a limit (the forecaster's own chance of this, stated with the estimate: 5%); at least 2.8-fold (0.45 log units) between middle value and limit.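

In this assay compound 4 gives > 20000 nM, which is a limit of the assay and not a number. Chloro in place of fluoro gave an at least 3.2-fold higher number from compound 3 to compound 4 (0.50 log units; beyond the scatter), so the near-absent step seen on the core of compound 1, a 1.1-fold higher number from compound 1 to compound 2 (0.04 log units; within the scatter), did not carry over to the core of compound 3: the same change on two cores in this assay, a 1.1-fold higher number (0.04 log units; within the scatter) from compound 1 to compound 2 and an at least 3.2-fold higher number (0.50 log units; beyond the scatter) from compound 3 to compound 4, at least 2.9-fold (0.46 log units) apart, beyond the scatter of two such steps This shows that the effect of this change depends on the core in these two pairs, but it does not show the full size of the step on the core of compound 3, nor which difference between the cores matters, and one end of that step is only a limit: the limit of > 20000 nM in this assay, at which 1 of the 4 values shown sits.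

The compounds shown carry only fluoro or chloro on this ring, and it remains open whether bromo, methyl or an amine there would behave as on the core of compound 1 or as on that of compound 3. Going by these compounds, it also remains open whether the gap goes with the nitro group itself, as a nitrile or a carboxylic acid in its stead could tell.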